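The source may hold more compounds than are shown below. What is called first, only, known or untested is meant among the compounds shown, and "the series" means these compounds.

Measured in an ADME assay on microsomes (Mus musculus) for metabolic stability; on this read-out higher numbers stand for fast clearance and lower numbers for slow clearance:
- compound 1 (`CNC(=O)[C@@H]1CCCN1S(=O)(=O)c1ccc(Cl)c(COc2cccc3c(C(F)(F)F)cc(C)nc23)c1Cl`) gives 1380 mL/min/kg
- compound 2 (`CCc1cc(C(F)(F)F)c2cccc(OCc3c(Cl)ccc(S(=O)(=O)N4CCC[C@H]4C(=O)NC)c3Cl)c2n1`) gives 1280 mL/min/kg

The series holds a single measured step: a 1.1-fold lower number from compound 1 to compound 2 (0.03 log units; within the scatter). Among the compounds with values here, compound 1 therefore stands level with the only other measured compound, and the pair gives no spread of values to work from.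

Compound 3 (`Cc1cc(C(F)(F)F)c2cccc(OCc3c(Cl)ccc(S(=O)(=O)N4CCC[C@H]4C(=O)O)c3Cl)c2n1`) is still to be measured. Its difference from compound 1 is hydroxy in place of methylamino on a carbonyl carbon. In words, this is hydroxy in place of methylamino on a carbonyl carbon, so methylcarbamoyl becomes carboxy.

The measured step bears on this only weakly. Within the data shown here, it is methyl in place of hydrogen on a saturated chain carbon bound to an aromatic carbon, a change elsewhere in the molecule, and no measured compound varies the group on the carbonyl carbon. The expectation in this assay is thus a judgement on the structural change alone: a step beyond the scatter, towards a lower number, with a wide margin. An estimated 3.1-fold lower number from compound 1 to compound 3 (0.49 log units; beyond the scatter) is what this amounts to. Compound 3 is expected near 450 mL/min/kg and estimated to fall from 120 mL/min/kg to 1400 mL/min/kg on measurement.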

Compound 3, clearance: 13.3 mL/min/kg
The estimate for compound 3 lay 34-fold (1.53 log units) above the measured number, and the stated range ends above it.
By their numbers in this assay, from the lowest: compound 3; then compounds 2 and 1 (each within the scatter of the next).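

In this assay the group on the carbonyl carbon proves to be a highly sensitive place: hydroxy in place of methylamino, with methylcarbamoyl becoming carboxy, gives a 100-fold lower number from compound 1 to compound 3 (2.02 log units; beyond the scatter) and takes the series well outside the narrow band of the first two compounds. Within the data shown here, the only earlier step, a 1.1-fold lower number from compound 1 to compound 2 (0.03 log units; within the scatter), came from a change elsewhere in the molecule and showed no such movement, so this is the first change seen to shift the read-out beyond the scatter. Nothing available explains the size of this step.

Going by these compounds, whether the low number belongs to the carboxy group itself or would also appear with a primary carboxamide, a methyl ester or a tetrazole on the same saturated ring carbon remains open, as does whether a longer chain on the amide nitrogen would keep the high number of compound 1. Equally open, on these data alone, is whether methyl in place of hydrogen on the saturated chain carbon would stay as silent with carboxy in place of methylcarbamoyl.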